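From Cyclopentyl to Cycloheptyl on an Aromatic Nitrogen

A few compounds are considered here, and "the series" means these few. Any claim that something is new, unique, unknown or untested is made for them only; others in the source may bear on it.

Measured in a functional assay on HT-29 cells (Homo sapiens) for inhibition, read by luminescence and CellTiter-Glo, with a stated time of 24 h; on this read-out lower numbers stand for an effect already at smaller amounts and higher numbers for an effect only at larger amounts of compound:
compound 1 `CCCCn1nc(C(=O)N[C@H]2COc3ccccc3N(C)C2=S)nc1Cc1ccccc1`: 510 nM
compound 2 `CN1C(=S)[C@@H](NC(=O)c2nc(Cc3ccccc3)n(C3CCCC3)n2)COc2ccccc21`: 3530 nM

Of these two compounds, compound 2 has the higher number, 3530 nM. Compound 3 `CN1C(=S)[C@@H](NC(=O)c2nc(Cc3ccccc3)n(C3CCCCCC3)n2)COc2ccccc21` differs from it in one place, with cycloheptyl in place of cyclopentyl on an aromatic nitrogen. Among the measured compounds shown here, only one measured step bears on this place, a modest one with cyclopentyl replacing butyl: a 6.9-fold higher number from compound 1 to compound 2 (0.84 log units; beyond the scatter). It does not show how a larger ring behaves, so no step beyond the scatter is expected in this assay, in either direction. The expected change is a 1.2-fold lower number from compound 2 to compound 3 (0.07 log units; within the scatter). Compound 3 is estimated at 3000 nM, within an expected range of 900 nM to 10000 nM.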

Compound 3, half-maximal effective concentration: 5530 nM
Compound 3: the middle estimate sits 1.8-fold (0.27 log units) below what was measured; low and high end bracket the measured number.
By their numbers in this assay, from the lowest: compound 1; then compounds 2 and 3 (each within the scatter of the next).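

In this assay, enlarging the ring on the aromatic nitrogen from cyclopentyl to cycloheptyl gives a 1.6-fold higher number from compound 2 to compound 3 (0.19 log units; within the scatter), so this change in ring size separates the two compounds by no more than the usual scatter. Replacing butyl with cycloheptyl gives an 11-fold higher number from compound 1 to compound 3 (1.04 log units; beyond the scatter), so both rings now stand apart from butyl at this position. Nothing available explains that separation. Still open, on these data alone, is whether a propyl chain, a branched isopropyl group or a ring carrying an amine would read like butyl or like the carbon rings.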